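Swapping a piperidine for a spirocyclic amine: solubility outlook

The compounds below may be only part of what the source reports. "The series", "measured", "known", "first", "only" and "open" are said of these compounds alone.

Measured compounds:
compound 1, `COc1ccc2[nH]c(C(=O)N3CC(=O)N(Cc4ccccc4)[C@@H](CN4CCC(C)CC4)C3)cc2c1`: 93100 nM
compound 2, `COc1ccc2[nH]c(C(=O)N3CC(=O)N(Cc4ccc[nH]4)[C@@H](Cc4ccccc4)C3)cc2c1`: 38400 nM

Of the compounds shown here, two sharing one core have been measured in a physicochemical assay for solubility, read by spectrophotometry, in phosphate buffer, with a stated time of 2 h, at pH 7.4; a higher number here means a more soluble compound, a lower number a less soluble compound. Compound 1 gives 93100 nM and compound 2 gives 38400 nM. Compound 1 therefore has the higher of the two numbers, and the gap to compound 2 is beyond the usual scatter of this assay. The two differ in more than one place, so no single change can be tied to that gap.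

Compound 3, `COc1ccc2[nH]c(C(=O)N3CC(=O)N(Cc4ccccc4)[C@@H](CN4CC5(CCC5)C4)C3)cc2c1`, has not yet been measured. It differs from compound 1 in one place only: a group of 7 heavy atoms (6 carbon, 1 nitrogen; one four-membered non-aromatic ring of carbon only, one four-membered non-aromatic ring with 1 hetero atom) in place of a group of 7 heavy atoms (6 carbon, 1 nitrogen; one six-membered non-aromatic ring with 1 hetero atom), on a saturated chain carbon bound to a saturated ring carbon. The rest of the molecule, including the benzyl group on the ring nitrogen and the shared core, is unchanged.

Among the measured compounds shown here, no measured pair shows this particular exchange, so there is no direct guide to its size. The exchange keeps the same count of heavy atoms and the same single hydrogen-bond acceptor, so a small change is expected, with the step from compound 1 to compound 3 estimated at a 1.3-fold higher number from compound 1 to compound 3 (0.11 log units; within the scatter), upward but close to the scatter. Compound 3 is expected to give about 120000 nM in this assay, within a range of 50000 nM to 300000 nM.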

Compound 3, solubility: 60700 nM
Estimate against measurement, compound 3: 2.0-fold (0.30 log units) above, within the range that was stated.
By their numbers in this assay, from the lowest: compounds 2, 3 and 1 (each within the scatter of the next, the first and the last beyond it).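

In this assay, among the compounds shown here, this is the first exchange at this position that can be read on its own, with nothing else in the molecule altered. On a saturated chain carbon bound to a saturated ring carbon, a group with two four-membered rings replaces 4-methylpiperidin-1-yl, and the result is a 1.5-fold lower number from compound 1 to compound 3 (0.19 log units; within the scatter), so the two groups cannot be told apart in this read-out, even though the ring sizes differ and the heavy-atom count stays the same. Nothing measured here bears on why the number falls where it does.

This single pair cannot show whether other groups at this position would also stay within the scatter, for example morpholine, an open-chain dimethylamino group or a piperidine without the methyl group. On these data alone, a carboxylic acid in place of the amine would be a larger change in kind, and it remains open whether any such replacement on the shared core would move the number beyond the scatter.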